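The source may report more compounds than this note shows. Statements on the series, on what has been measured and on what is new or still open speak of the compounds shown alone.

Measured compounds in a functional assay on HCT-116 cells (Homo sapiens) for antiproliferative activity, read by MTT assay, with a stated time of 24 h; a lower number here means a stronger inhibitor, a higher number a weaker inhibitor: compound 1 `COc1cc(OC)c(-c2coc3cc(OCC(=O)c4cccc(C(F)(F)F)c4)ccc3c2=O)cc1OC`. Compound 2 `COc1cc(OC)c(-c2coc3cc(OCc4ccc(F)cc4)ccc3c2=O)cc1OC`. Compound 3 `COc1cc(OC)c(-c2coc3cc(OCc4ccccc4C(F)(F)F)ccc3c2=O)cc1OC`.

In this assay compound 1 gives > 10000 nM, which is a limit of the assay and not a number; compound 1 therefore stands at the limit of > 10000 nM in this assay, at which 1 of the 3 values shown sits. Compound 2 gives 950 nM. Compound 3 gives 4760 nM.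

Compound 4 `COc1cc(OC)c(-c2coc3cc(OCc4cccc(Br)c4)ccc3c2=O)cc1OC` differs from compound 1 in one place: 3-bromophenyl in place of (3-(trifluoromethyl)phenyl)carbonyl on a saturated chain carbon bound to an oxygen on an aromatic ring. Two measured steps remove the same carbonyl-bearing group from compound 1: an at least 10-fold lower number from compound 1 to compound 2 (1.02 log units; beyond the scatter) and an at least 2.1-fold lower number from compound 1 to compound 3 (0.32 log units; beyond the scatter). Between the two resulting benzyl ethers the gap is a 5.0-fold higher number from compound 2 to compound 3 (0.70 log units; beyond the scatter). A step in the same direction, of a size between those two, is therefore expected for compound 4, estimated as an at least 4.5-fold lower number from compound 1 to compound 4 (0.65 log units; beyond the scatter). The expected value for compound 4 in this assay is 2200 nM, within a range of 700 nM to 7000 nM.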

Compound 4, half-maximal inhibitory concentration: 1200 nM
Estimate against measurement, compound 4: 1.8-fold (0.26 log units) above, and the stated range covers the measured number.
By their numbers in this assay, from the lowest: compounds 2 and 4 (each within the scatter of the next); then compound 3. At a limit, above all of these: compound 1.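

Compound 1 holds a limit of the assay and not a number: the limit of > 10000 nM in this assay, at which 1 of the 4 values shown sits. A third benzyl ether gives an at least 8.3-fold lower number from compound 1 to compound 4 (0.92 log units; beyond the scatter), so the gain on losing the (3-(trifluoromethyl)phenyl)carbonyl does not rest on compound 2 and compound 3 alone. On this saturated chain carbon, 3-bromophenyl and 4-fluorophenyl do not separate, with a 1.3-fold higher number from compound 2 to compound 4 (0.10 log units; within the scatter), whereas 2-(trifluoromethyl)phenyl stands apart, with a 4.0-fold lower number from compound 3 to compound 4 (0.60 log units; beyond the scatter), and compound 3 goes against any reading that all benzyl ethers here sit alike.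

The compounds shown do not separate the ring substituent from its place on the ring. From the compounds shown here alone, what an amine or a carboxylic acid on this ring would do remains open.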